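The source may hold more compounds than are shown below. What is called first, only, known or untested is meant among the compounds shown, and "the series" means these compounds.

Working notes on the series. Compound 1 `CC(C)C[C@]1(O)NC(=O)[C@]2(OC(Cc3ccccc3)=CC2=O)[C@H]1O` is one of two cores; the other core is carried by compound 3 `CC(C)CC(=O)C1Oc2cc(Cc3ccccc3)[nH]c(=O)c2O1` and compound 2 `Cc1cc2c(c(=O)[nH]1)OC(C(=O)CC(C)C)O2`. How the two cores differ is not broken down here. In an ADME assay on MRC5 cells (Homo sapiens) for cytotoxicity, read by WST assay, with a stated time of 48 h (a higher number here means a weaker inhibitor, a lower number a stronger inhibitor), compound 1 gives only a limit of the assay, > 50000 nM. In this assay compound 3 likewise gives only a limit, > 50000 nM. In this assay compound 2 also gives only a limit, > 50000 nM. Hence the change hydrogen in place of phenyl on a saturated chain carbon bound to an aromatic carbon yields a step that the two limits leave unreadable from compound 3 to compound 2, since (the limit of > 50000 nM in this assay, at which 3 of the 3 values shown sit). Compound 4 `CC1=CC(=O)[C@]2(O1)C(=O)N[C@@](O)(CC(C)C)[C@@H]2O` carries the same kind of change on the core of compound 1, (hydrogen in place of phenyl on a saturated chain carbon bound to a double-bonded ring carbon), the place differing in that the chain carbon is bound to a double-bonded ring carbon rather than an aromatic carbon. Because (the limit of > 50000 nM in this assay, at which 3 of the 3 values shown sit), the step from compound 1 to compound 4 is expected to be small, a number no higher from compound 1 to compound 4 (the limit leaves the size open). Compound 4 is accordingly estimated at 50000 nM in this assay, most likely again reported only as a limit.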

Compound 4, half-maximal inhibitory concentration: > 50000 nM
Compound 4 gave a limit, no number; the forecaster's own chance of this, stated with the estimate: 85%; the middle value lies on the limit itself.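

No new step can be read from compound 1 to compound 4 in this assay, since both compounds give only a limit: the limit of > 50000 nM in this assay, at which 4 of the 4 values shown sit.

The compounds shown leave open whether hydrogen in place of phenyl changes the read-out on either core.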